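The source may hold more compounds than are shown below. What is called first, only, known or untested is meant among the compounds shown, and "the series" means these compounds.

Series notes. Among the compounds with values here, in a functional assay on Ramos cells (Homo sapiens) for antiproliferative activity, read by CCK-8 assay, with a stated time of 72 h, tested at 40 uM (a higher number here means more inhibition at the concentration tested (going by the name of the read-out), a lower number less inhibition), the three measured members sit as follows. Compound 1 `CCOC(=O)c1sc(-c2cccc(NC(=O)c3ccc(C(F)(F)F)cn3)c2)nc1Nc1ccc(N2CCN(C)CC2)cc1` gives 19%. Compound 2 `CN1CCN(c2ccc(Nc3nc(-c4cccc(NC(=O)c5ccc(F)cc5)c4)sc3C(N)=O)cc2)CC1` gives 95.9%, and compound 3 `CN1CCN(c2ccc(Nc3nc(-c4cccc(NC(=O)c5ccc(F)c(Cl)c5)c4)sc3C(N)=O)cc2)CC1` gives 97.5%. Compound 3 carries the highest number of the three, but the gap a number 1.6 percentage points higher from compound 2 to compound 3 (within the scatter) leaves compound 2 and compound 3 indistinguishable; only compound 1 lies clearly apart from both.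

Compound 4 `CN1CCN(c2ccc(Nc3nc(-c4cccc(NC(=O)c5ccc(C(F)(F)F)cn5)c4)sc3C(N)=O)cc2)CC1` is reached from compound 3 by 5-(trifluoromethyl)pyridin-2-yl in place of 3-chloro-4-fluorophenyl on a carbonyl carbon. Within the data shown here, no measured step mirrors this exchange. Among the measured compounds shown here, the one step in hand, a number 1.6 percentage points higher from compound 2 to compound 3 (within the scatter), alters the group on the carbonyl carbon only by a chloro in place of hydrogen and stays within the scatter, so it says little about a swap of the whole ring. Compound 1 bears the same 5-(trifluoromethyl)pyridin-2-yl carbonyl as compound 4 and gives a low number, yet compound 1 also differs from compound 4 elsewhere in the core, so its value cannot be read as a step for this change alone. The expectation for compound 4 is therefore a step of a number 27.5 percentage points lower from compound 3 to compound 4 (beyond the scatter), expected downward but with wide uncertainty. Compound 4 is estimated at 70%, expected to fall between 30% and 97%.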

Compound 4, a percentage reported as inhibition, at one concentration (the size of the read-out at that concentration, not a potency): 96.6%
Compound 4: middle estimate off by 26.6 percentage points, on the low side, within the range that was stated.
By their numbers in this assay, from the lowest: compound 1; then compounds 2, 4 and 3 (each within the scatter of the next).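

In this assay, the change of the whole ring on the carbonyl carbon whose other neighbour is the amide-type nitrogen leaves no readable difference: the steps are a number 0.9 percentage points lower from compound 3 to compound 4 (within the scatter) and a number 0.7 percentage points higher from compound 2 to compound 4 (within the scatter), so 5-(trifluoromethyl)pyridin-2-yl, 3-chloro-4-fluorophenyl and 4-fluorophenyl cannot be told apart here. With 5-(trifluoromethyl)pyridin-2-yl held constant, amino in place of ethoxy on the other carbonyl carbon gives a number 77.6 percentage points higher from compound 1 to compound 4 (beyond the scatter), which ties the low number of compound 1 to the ethoxy group and not to the 5-(trifluoromethyl)pyridin-2-yl carbonyl, at least in this pair. Nothing measured here accounts for either the flat ring exchange or the large amino-for-ethoxy step.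

Compounds 2, 3 and 4 all sit close together at the top of a read-out taken at one concentration, so any difference in potency among them stays hidden, and a dose-response measure would be needed to separate them. Also open, on these data alone, is whether a methylamino group or a carboxylic acid at the amino-bearing carbonyl, or a saturated ring such as cyclohexyl on the other carbonyl, would hold numbers of this size.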